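Neopentyl for tert-butyl carried across two cores

A few compounds are considered here, and "the series" means these few. Any claim that something is new, unique, unknown or untested is made for them only; others in the source may bear on it.

The series is read in a functional assay on a cell-free system (plasma, Homo sapiens), with a stated time of 3 min; on this read-out higher numbers stand for weaker inhibition and lower numbers for stronger inhibition. Compound 3 `CC(C)(C)[C@@H](O)C(=O)N1CC[C@@H]2C[C@@]21C(=O)NCc1cc(Cl)ccc1-n1cnnn1` gives 1500 nM in this assay. Compound 1 `CC(C)(C)C[C@@H](O)C(=O)N1CC[C@@H]2C[C@@]21C(=O)NCc1cc(Cl)ccc1-n1cnnn1` carries the change neopentyl in place of tert-butyl on a saturated chain carbon bound to a carbonyl carbon and an oxygen on a saturated carbon and gives 620 nM in this assay; the step of a 2.4-fold lower number from compound 3 to compound 1 (0.38 log units; beyond the scatter). Compound 2 `CC(C)(C)[C@@H](O)C(=O)N1NCC[C@H]1C(=O)NCc1cc(Cl)ccc1-n1cnnn1` sits on another core; the difference between the two cores is not broken down here. In this assay compound 2 gives 1700 nM, a number that stands within the scatter of compound 3 and beyond it against compound 1.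

Compound 4 `CC(C)(C)C[C@@H](O)C(=O)N1NCC[C@H]1C(=O)NCc1cc(Cl)ccc1-n1cnnn1` is not yet measured. For the measured compounds named here, it differs from compound 2 by neopentyl in place of tert-butyl on a saturated chain carbon bound to a carbonyl carbon and an oxygen on a saturated carbon, the same change at the same place as the one made from compound 3 to compound 1. The expectation for compound 4 rests on compound 2 at 1700 nM and on the step of a 2.4-fold lower number from compound 3 to compound 1 (0.38 log units; beyond the scatter) carried over unchanged. Going by the values given here, the expected step is a 2.4-fold lower number from compound 2 to compound 4 (0.39 log units; beyond the scatter), matching the earlier one in size, with the reservation that a single occurrence is the only precedent and the core is not the same. Compound 4 is therefore estimated at 700 nM, with an expected range from 350 nM to 1400 nM.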

Compound 4, half-maximal inhibitory concentration: 1300 nM
Compound 4: the middle estimate sits 1.9-fold (0.27 log units) below what was measured; measured number inside the range.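

On the second core, neopentyl in place of tert-butyl gives a 1.3-fold lower number from compound 2 to compound 4 (0.12 log units; within the scatter) in this assay, so the step beyond the scatter seen on the core of compound 3 does not recur there as a step beyond the scatter. Set side by side, the two steps cannot be told apart: the same change on two cores in this assay, a 2.4-fold lower number (0.38 log units; beyond the scatter) from compound 3 to compound 1 and a 1.3-fold lower number (0.12 log units; within the scatter) from compound 2 to compound 4, 1.9-fold (0.27 log units) apart, within the scatter of two such steps

For the compounds shown here, this shows that the data are compatible with one shared effect of the change on both cores, but it does not establish that the effect carries over, nor that the core alters it, since each core offers a single pair and only one of the two steps lies beyond the scatter.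

The compounds shown leave open how this assay responds to anything other than tert-butyl and neopentyl on a saturated chain carbon bound to a carbonyl carbon and an oxygen. A longer chain, a cyclohexyl group or an amine at that place, on both cores, would show whether the two cores follow each other.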